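From Butylsulfanyl to Methylsulfanyl: Cytotoxicity Stays at the Limit

The source may report more compounds than this note shows. Statements on the series, on what has been measured and on what is new or still open speak of the compounds shown alone.

Of the compounds shown here, three sharing the same core have been tested in an ADME assay on BCBL1 cells (Homo sapiens) for cytotoxicity, with a stated time of 7 days; on this read-out lower numbers stand for higher toxicity in this test and higher numbers for lower toxicity in this test. Compound 1 `CCCCCCCCOc1nc(N)nc2c1ncn2/C=C1/CC1(CO)CO` gives > 20000 nM in this assay, which is a limit of the assay and not a number. Compound 2 `CCCCSc1nc(N)nc2c1ncn2/C=C1/CC1(CO)CO` likewise reaches only a limit, > 20000 nM in this assay. Compound 3 `CCCCCCSc1nc(N)nc2c1ncn2/C=C1/CC1(CO)CO` also sits at a limit, > 20000 nM in this assay. Because (the limit of > 20000 nM in this assay, at which 3 of the 3 values shown sit), none of the steps among them can be read: a step that the two limits leave unreadable from compound 1 to compound 2, a step that the two limits leave unreadable from compound 1 to compound 3 and a step that the two limits leave unreadable from compound 2 to compound 3 are all of unreadable size.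

Compound 4 `CSc1nc(N)nc2c1ncn2/C=C1/CC1(CO)CO` has not yet been measured. It differs from compound 2 by hydrogen in place of propyl on a saturated chain carbon bound to a sulfur. The measured steps that bear on this change are those along the same chain, and each is hidden by the limit, so no direction can be taken from them. Compound 2 stands at the limit, and the change shortens the same chain that compounds 2 and 3 already vary without leaving the limit. Compound 4 is therefore expected to stay at the limit as well, the estimated step being a step that the limit leaves unreadable from compound 2 to compound 4. The estimate for compound 4 in this assay is 30000 nM, expected to lie between 15000 nM and 80000 nM.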

Compound 4, half-maximal cytotoxic concentration: > 20000 nM
Compound 4 was reported as a limit (the forecaster's own chance of this, stated with the estimate: 85%); the middle value is on the limit's open side.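

Compound 4 stays at a limit of the assay, as do compound 1, compound 2 and compound 3, so no step from or to compound 4 can be read in this assay: the limit of > 20000 nM in this assay, at which 4 of the 4 values shown sit.

The compounds shown leave open whether any of these groups, from methylsulfanyl to octyloxy, differs from the others in cytotoxicity, and by how much.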